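Amino in place of methoxy: working notes toward compound 4

This account rests on a few compounds, and the source may have more. Where it says the series, first, only, none or still open, it means among the compounds named here.

Of the compounds shown here, three of the shared core have been measured in a functional assay on PC-3 cells (Homo sapiens) for cytotoxicity, read by MTT assay, with a stated time of 72 h; on this read-out higher numbers stand for weaker inhibition and lower numbers for stronger inhibition. Compound 1 `Nc1ccc(Nc2nc3ccccc3nc2S(=O)(=O)c2ccccc2)cc1` gives 5830 nM. Compound 2 `Cc1ccc(S(=O)(=O)c2nc3ccccc3nc2Nc2ccc(N)cc2)cc1` gives 5000 nM. Compound 3 `COc1ccc(Nc2nc3ccccc3nc2S(=O)(=O)c2ccc(F)cc2)cc1` gives 4330 nM. On these numbers compound 3 carries the lowest value of the three, but its gaps to compound 2 and to compound 1 both lie within the scatter, so no order among the three can be read from them. Going by the values given here, the one single-point step measured so far, a 1.2-fold lower number from compound 1 to compound 2 (0.07 log units; within the scatter), is a methyl in place of hydrogen on an aromatic carbon of the sulfonyl-bearing ring and is itself within the scatter.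

Compound 4 `Nc1ccc(Nc2nc3ccccc3nc2S(=O)(=O)c2ccc(F)cc2)cc1` is not yet measured. It differs from compound 3 by amino in place of methoxy on an aromatic carbon, placed on an aromatic carbon of a six-membered aromatic ring of carbon only, para to a large group. Among the compounds with values here, no measured step touches this ring, so nothing bears directly on the change. Compound 4 keeps the fluorine of compound 3 and the amino of compound 1 and compound 2, whose values all sit close together. The step from compound 3 to compound 4 is therefore expected to be a 1.2-fold higher number from compound 3 to compound 4 (0.06 log units; within the scatter), with no movement beyond the scatter. For compound 4 the expected value in this assay is 5000 nM, within a range of 2500 nM to 10000 nM.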

Compound 4, half-maximal inhibitory concentration: 2050 nM
The estimate for compound 4 lay 2.4-fold (0.39 log units) above the measured number, and the stated range ends above it.
By their numbers in this assay, from the lowest: compound 4; then compounds 3, 2 and 1 (each within the scatter of the next).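

In this assay, going by these compounds alone, amino in place of methoxy on an aromatic carbon, para to a large group, gives the first step on this ring, and it lies beyond the scatter, though modest in size (a 2.1-fold lower number from compound 3 to compound 4 (0.32 log units; beyond the scatter)). The sulfonyl-bearing ring also moves the number once amino is held: fluoro in place of methyl gives a step beyond the scatter (a 2.4-fold lower number from compound 2 to compound 4 (0.39 log units; beyond the scatter)), as does fluoro in place of hydrogen (a 2.8-fold lower number from compound 1 to compound 4 (0.45 log units; beyond the scatter)), whereas methyl in place of hydrogen stays within it (a 1.2-fold lower number from compound 1 to compound 2 (0.07 log units; within the scatter)), so among these four only compound 4, which carries both the fluorine and the amino, stands apart from the others. No measurement shown here bears on the cause of these steps.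

Going by these compounds, whether the step from methoxy belongs to amino itself, or would also appear with a hydroxyl or a dimethylamino group at the same place, stays open. Also open, on these data alone, is whether a chlorine in place of the fluorine would keep the number that compound 4 gives (2050 nM), and whether the exchange of methoxy for amino has the same size on a sulfonyl-bearing ring without fluorine.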